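The source may report more compounds than this note shows. Statements on the series, on what has been measured and on what is new or still open speak of the compounds shown alone.

Measured so far in a physicochemical assay for metabolic stability, read by HPLC, in phosphate buffer, at pH 7.3 (on this read-out lower numbers stand for a shorter-lived compound and higher numbers for a longer-lived compound), are two compounds:
Compound 1 `CCCCCCCCCCCCCCCCOC(=O)Oc1ccc(COP(=O)(OCc2ccc(OC(=O)CC)cc2)OP(=O)(O)OP(=O)(O)OC[C@H]2O[C@@H](n3cc(C)c(=O)[nH]c3=O)C[C@@H]2N=[N+]=[N-])cc1` at 83 h 
Compound 2 `CCCCCCCCCCCCCCCCOC(=O)Oc1ccc(COP(=O)(OCc2ccc(OC(=O)CC)cc2)OP(=O)(O)OP(=O)(O)OC[C@H]2O[C@@H](n3cc(/C=C/Br)c(=O)[nH]c3=O)C[C@@H]2O)cc1` at 56 h 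

Compound 2 at 56 h lies within the usual scatter of compound 1, so these two numbers cannot be told apart. Compound 3 `CCCCCCCCCCCCCCCCOC(=O)Oc1ccc(COP(=O)(OCc2ccc(OC(=O)CC)cc2)OP(=O)(O)OP(=O)(O)OC[C@H]2O[C@@H](n3cc(C)c(=O)[nH]c3=O)C[C@@H]2O)cc1` is still unmeasured and carries methyl in place of 2-bromoethenyl on an aromatic carbon and nothing else differs. For the measured compounds named here, no measured pair shows this change alone. Compound 1 also carries methyl there, though it differs elsewhere, and its 83 h gives no sign of a large shift. In this assay the estimated step of a 1.2-fold higher number from compound 2 to compound 3 (0.06 log units; within the scatter) stays within the scatter, with no firm direction expected. Estimated for compound 3 is 65 h with 35 h to 120 h as the expected range.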

Compound 3, half-life: 76 h
Compound 3: the middle estimate sits 1.2-fold (0.07 log units) below what was measured; the measured number falls inside the stated range.
By their numbers in this assay, from the lowest: compounds 2, 3 and 1 (each within the scatter of the next).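

Compound 2 and compound 3 differ only on this aromatic carbon, so in this assay the swap of 2-bromoethenyl for methyl can now be read alone: a 1.4-fold higher number from compound 2 to compound 3 (0.13 log units; within the scatter) and the two numbers cannot be told apart. Hydroxy in place of azido on the saturated ring carbon, also seen alone, gives a 1.1-fold lower number from compound 1 to compound 3 (0.04 log units; within the scatter) and the same holds. Nothing available gives a reason for either result. On these data alone, whether an amine or a carboxylic acid on this aromatic carbon would move the number beyond the scatter stays open.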